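A Chlorine Added to the Phenyl Ring of Compound 3

The source may report more compounds than this note shows. Statements on the series, on what has been measured and on what is new or still open speak of the compounds shown alone.

Three measured compounds share one core and differ only in the group on a phenyl ring. Compound 1 `COc1ccc(-c2nc(C)c(C(=O)CSc3nc(-c4ccc(OC)cc4)c(C#N)c(=O)[nH]3)s2)cc1` gives 25300 nM in a functional assay on U-87MG ATCC cells for antiproliferative activity against U-87 MG (Homo sapiens), read by MTT assay, with a stated time of 48 h; a lower number here means a stronger inhibitor, a higher number a weaker inhibitor; compound 2 `COc1ccc(-c2nc(C)c(C(=O)CSc3nc(-c4ccc(Cl)cc4)c(C#N)c(=O)[nH]3)s2)cc1` gives 45900 nM; compound 3 `COc1ccc(-c2nc(C)c(C(=O)CSc3nc(-c4ccccc4)c(C#N)c(=O)[nH]3)s2)cc1` gives 57300 nM, the highest of the three numbers, though its gap to compound 2 is within the scatter, and the step of a 2.3-fold higher number from compound 1 to compound 3 (0.36 log units; beyond the scatter) is only modest. Compound 4 `COc1ccc(-c2nc(C)c(C(=O)CSc3nc(-c4cccc(Cl)c4)c(C#N)c(=O)[nH]3)s2)cc1` carries the change (chloro in place of hydrogen on an aromatic carbon). Within the data shown here, no measured step puts chlorine at this place; the nearest guide is a 1.2-fold higher number from compound 2 to compound 3 (0.10 log units; within the scatter), where a chlorine elsewhere on the same ring made no difference beyond the scatter. A step of a 1.1-fold lower number from compound 3 to compound 4 (0.06 log units; within the scatter) is therefore expected, essentially none. Compound 4 is estimated at 50000 nM, with a range from 20000 nM to 120000 nM.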

Compound 4, half-maximal inhibitory concentration: 78900 nM
Beside the measured number, compound 4's estimate is 1.6-fold (0.20 log units) below it, and the stated range covers the measured number.
By their numbers in this assay, from the lowest: compounds 1, 2, 3 and 4 (each within the scatter of the next, the first and the last beyond it).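

In this assay, chlorine at this place on the phenyl ring brings no change beyond the scatter (a 1.4-fold higher number from compound 3 to compound 4 (0.14 log units; within the scatter)). Moving the chlorine to this place from its position in the chlorinated comparison compound is also within the scatter (a 1.7-fold higher number from compound 2 to compound 4 (0.24 log units; within the scatter)). Only the replacement of the methoxy-bearing phenyl ring by 3-chlorophenyl goes beyond the scatter, and only modestly (a 3.1-fold higher number from compound 1 to compound 4 (0.49 log units; beyond the scatter)). Nothing available explains these differences. Chlorine is the only group shown at this place, so the effect of an amine, a carboxylic acid or a longer chain there remains open.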